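Cyclopropylamine in place of the acetamidoethylamine side chain

The compounds below may be only part of what the source reports. "The series", "measured", "known", "first", "only" and "open" are said of these compounds alone.

Three compounds sharing the core of compound 1 `COc1cc(Oc2cccc(Nc3ccccc3)c2)cc(OC)c1CNCCNC(C)=O` have been tested in a functional assay on HCT-15 cells (Homo sapiens) for inhibition, read by MTT assay, with a stated time of 72 h; a lower number here means a stronger inhibitor, a higher number a weaker inhibitor. Compound 1 gives 5090 nM, the second highest of the three numbers. Compound 2 `COc1cc(Oc2cccc(Nc3ccccc3)c2)cc(OC)c1CNCc1ccc(Cl)cc1` gives 4850 nM, and the step of a 1.0-fold lower number from compound 1 to compound 2 (0.02 log units; within the scatter) lies within the scatter. Compound 3 `COc1cc(Oc2cccc(Nc3ccccc3)c2)cc(OC)c1CCO` gives 12100 nM; the steps of a 2.4-fold higher number from compound 1 to compound 3 (0.38 log units; beyond the scatter) and a 2.5-fold higher number from compound 2 to compound 3 (0.40 log units; beyond the scatter) are both modest and both beyond the scatter.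

Compound 4 `COc1cc(Oc2cccc(Nc3ccccc3)c2)cc(OC)c1CNC1CC1` is the next in line. It differs from compound 1 as follows: cyclopropyl in place of 2-acetamidoethyl on an amine nitrogen. Cut one bond further out, this reads (2-acetamidoethyl)amino to cyclopropylamino.

The step of a 1.0-fold lower number from compound 1 to compound 2 (0.02 log units; within the scatter) bears most directly on this change, since there too the group on the amine nitrogen was exchanged while the amine itself was kept, and the number barely moved. The steps of a 2.4-fold higher number from compound 1 to compound 3 (0.38 log units; beyond the scatter) and a 2.5-fold higher number from compound 2 to compound 3 (0.40 log units; beyond the scatter) concern removal of the amine altogether, which compound 4 does not do. The expected step of a 1.1-fold higher number from compound 1 to compound 4 (0.03 log units; within the scatter) is therefore small, with no direction to be read from the data. Compound 4 is estimated at 5500 nM, in a range from 2500 nM to 12000 nM.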

Compound 4, half-maximal inhibitory concentration: 6140 nM
Beside the measured number, compound 4's estimate is 1.1-fold (0.05 log units) below it; measured number inside the range.
By their numbers in this assay, from the lowest: compounds 2, 1, 4 and 3 (each within the scatter of the next, the first and the last beyond it).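

In this assay a small carbocycle on the amine nitrogen serves no differently from the two larger groups: cyclopropyl replaces 2-acetamidoethyl with no readable change (a 1.2-fold higher number from compound 1 to compound 4 (0.08 log units; within the scatter)), and it replaces 4-chlorobenzyl with none either (a 1.3-fold higher number from compound 2 to compound 4 (0.10 log units; within the scatter)). The amide and the chlorophenyl ring can thus each be absent from this nitrogen without a shift beyond the scatter. The amine series also separates less cleanly from the hydroxymethyl compound 3 than before, since compound 4 stays within the scatter of it (a 2.0-fold lower number from compound 3 to compound 4 (0.29 log units; within the scatter)), whereas compound 1 and compound 2 lie beyond it; no supporting measurement bears on this result.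

Still open, as far as these compounds go, is whether a primary amine, or a carboxylic acid on the chain, would move the number beyond the scatter. The compounds shown also leave open whether any group on this nitrogen gives a clearly lower number.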